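This account rests on a few compounds, and the source may have more. Where it says the series, first, only, none or still open, it means among the compounds named here.

In a functional assay on the whole organism (strain Sprague-Dawley) for inhibition, with Rattus norvegicus as the target, with a stated time of 10 min (on this read-out lower numbers stand for an effect already at smaller amounts and higher numbers for an effect only at larger amounts of compound), compound 1 `O=C(O)c1cnc(-c2ccccc2[N+](=O)[O-])[nH]c1=O`, which carries a nitro group, gives > 50 mg/kg, and this is a limit of the assay, not a number. Compound 2 `COc1ccccc1-c1ncc(C(=O)O)c(=O)[nH]1`, with methoxy in place of nitro, gives 10 mg/kg. For the measured compounds named here, compound 3 `CC(C)COc1ccccc1-c1ncc(C(=O)O)c(=O)[nH]1`, with isobutoxy there, gives 0.5 mg/kg, the lowest number so far, and compound 2 is its nearest neighbour.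

Compound 4 `CCCCCOc1ccccc1-c1ncc(C(=O)O)c(=O)[nH]1` is still unmeasured. Its difference from compound 3 is butyl in place of isopropyl on a saturated chain carbon bound to an oxygen on an aromatic ring, so isobutoxy becomes pentyloxy.

Going by the values given here, three measured steps bear on this change. Replacing nitro gave an at least 5.0-fold lower number from compound 1 to compound 2 (0.69 log units; beyond the scatter) with methoxy and an at least 100-fold lower number from compound 1 to compound 3 (2.00 log units; beyond the scatter) with isobutoxy. Among the compounds with values here, the closest precedent, at the same place, is a 20-fold lower number from compound 2 to compound 3 (1.30 log units; beyond the scatter), where isopropyl replaced hydrogen. These steps are sizeable, but none exchanges one carbon chain for another, as the move to compound 4 does. Only a small shift is therefore expected, with no step beyond the scatter and perhaps a slight drift upward. The expected change is a 1.6-fold higher number from compound 3 to compound 4 (0.20 log units; within the scatter). For compound 4 the estimated value is 0.8 mg/kg, with an expected range from 0.2 mg/kg to 4 mg/kg.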

Compound 4, dose for 50% inhibition: 3 mg/kg
Compound 4: the middle estimate sits 3.8-fold (0.57 log units) below what was measured; measured number inside the range.
By their numbers in this assay, from the lowest: compound 3; then compound 4; then compound 2. At a limit, above all of these: compound 1.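

In this assay, the result shows that at this place the form of the carbon chain matters, and not only its presence: exchanging isopropyl for butyl, which turns isobutoxy into pentyloxy, gives a 6.0-fold higher number from compound 3 to compound 4 (0.78 log units; beyond the scatter), even though neither group brings a ring, a hydrogen-bond donor or acceptor, or a charge. Pentyloxy still improves on the small methoxy group, with a 3.3-fold lower number from compound 2 to compound 4 (0.52 log units; beyond the scatter), so a larger chain on the oxygen keeps part of the gain, but less of it than isobutoxy in compound 3. Pentyloxy in place of nitro gives an at least 16-fold lower number from compound 1 to compound 4 (1.22 log units; beyond the scatter), and this step rests on a limit of the assay for compound 1: the limit of > 50 mg/kg in this assay, at which 1 of the 4 values shown sits.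

As far as these compounds go, what remains open is whether the branch or the chain length separates compound 3 from compound 4, and a straight butoxy group or a longer branched chain such as isopentyloxy at this place would help to tell these apart. From the compounds shown here alone, it is also open how a chain ending in an amine or a carboxylic acid would fare in this assay.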